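Lengthening the Hydroxy Chain by One Carbon

The compounds below may be only part of what the source reports. "The series", "measured", "known", "first", "only" and "open" are said of these compounds alone.

Compound 1 `CC(C)Cn1c(=O)n(C)c(=O)c2[nH]c(=O)c(Cc3cccc4ccccc34)nc21`: > 10000 nM (a limit, not a number)
Compound 2 `CC(C)Cn1c(=O)n(C)c(=O)c2c1nc(Cc1cccc3ccccc13)c(=O)n2CCCCO`: 150 nM

For the measured compounds named here, both come from a functional assay on Raji cells (Homo sapiens) for inhibition, read by MTT assay, with a stated time of 96 h (on this read-out lower numbers stand for an effect already at smaller amounts and higher numbers for an effect only at larger amounts of compound), and compound 2 holds the only true number there (150 nM). Compound 3 `CC(C)Cn1c(=O)n(C)c(=O)c2c1nc(Cc1cccc3ccccc13)c(=O)n2CCCCCO` carries a longer chain: hydroxymethyl in place of hydroxy on a saturated chain carbon, four bonds along the chain from an aromatic nitrogen with hydroxymethyl in place of hydroxy on a saturated chain carbon, four bonds along the chain from an aromatic nitrogen. Going by the values given here, the one measured step (an at least 66-fold lower number from compound 1 to compound 2 (1.82 log units; beyond the scatter)) was large, but it put 4-hydroxybutyl in place of hydrogen on an aromatic nitrogen, whereas compound 3 only extends that chain, so in this assay no step beyond the scatter is expected, in either direction. The expected step is small (a 1.2-fold higher number from compound 2 to compound 3 (0.08 log units; within the scatter)). For compound 3 the estimated value is 180 nM (expected range 60 nM to 550 nM).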

Compound 3, half-maximal effective concentration: 1420 nM
Compound 3: the middle estimate sits 7.9-fold (0.90 log units) below what was measured; the whole stated range lies below it.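

In this assay, the length of the chain on the aromatic nitrogen matters: hydroxymethyl in place of hydroxy gives a 9.5-fold higher number from compound 2 to compound 3 (0.98 log units; beyond the scatter), so even this small extension is not neutral at this position. The 5-hydroxypentyl chain still keeps part of the gain over hydrogen on that nitrogen, with an at least 7.0-fold lower number from compound 1 to compound 3 (0.84 log units; beyond the scatter). Nothing measured here accounts for the difference between the two chains. On these data alone, whether a shorter 3-hydroxypropyl chain would give a lower number than 4-hydroxybutyl stays open. So does whether an amine at the chain end could stand in for the hydroxy.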